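A few compounds are considered here, and "the series" means these few. Any claim that something is new, unique, unknown or untested is made for them only; others in the source may bear on it.

Compound 1 `COC1CN(C(=O)/C=C/c2ccncc2-c2ccc3ccccc3c2)C1` and compound 2 `CNC(=O)/C=C/c1ccncc1-c1ccc2ccccc2c1` share a core and differ only in the group on the carbonyl carbon. In a functional assay on HCT-116 cells (Homo sapiens) for inhibition, read by MTT assay, with a stated time of 72 h (a higher number here means a weaker inhibitor of growth, a lower number a stronger inhibitor of growth), compound 1 gives only a limit, > 30000 nM, the same limit described as the limit of > 30000 nM in this assay, at which 1 of the 2 values shown sits. In this assay, within the data shown here, compound 2 gives 6550 nM, the only actual number among the measured values. Among the measured compounds shown here, the single measured step, an at least 4.5-fold lower number from compound 1 to compound 2 (0.66 log units; beyond the scatter), is thus read against a limit and concerns methylamino in place of 3-methoxyazetidin-1-yl on the carbonyl carbon.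

Compound 3 `O=C(/C=C/c1ccncc1-c1ccc2ccccc2c1)NC1CC1` follows from compound 2 by cyclopropyl in place of methyl on an amide-type nitrogen. The measured step also altered the group on the carbonyl carbon, but it exchanged a ring amine for methylamino, whereas the present change keeps the amide hydrogen and only enlarges the substituent on the amide-type nitrogen. For the measured compounds named here, no measured pair speaks to such an exchange, so the expected change, a 1.3-fold lower number from compound 2 to compound 3 (0.12 log units; within the scatter), stays within the scatter. Compound 3 is therefore expected to give 5000 nM, with a range from 1500 nM to 16000 nM.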

Compound 3, concentration for 50% growth inhibition: 6180 nM
Compound 3: middle estimate off by 1.2-fold (0.09 log units), on the low side, within the range that was stated.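

In this assay, cyclopropyl on the amide-type nitrogen, which brings in a three-membered non-aromatic ring of carbon only, gives a 1.1-fold lower number from compound 2 to compound 3 (0.03 log units; within the scatter), so at this position the ring and methyl cannot be told apart. With cyclopropylamino in place of 3-methoxyazetidin-1-yl on the carbonyl carbon, the step reads an at least 4.8-fold lower number from compound 1 to compound 3 (0.68 log units; beyond the scatter), which shows that the lower number seen earlier with methylamino is not confined to that one group. That step rests on a limit held by compound 1, which is no number: the limit of > 30000 nM in this assay, at which 1 of the 3 values shown sits.

Going by these compounds, it remains open whether a longer chain such as n-butyl, a larger ring such as cyclohexyl, or a chain ending in an amine or a carboxylic acid on the amide-type nitrogen would shift the number beyond the scatter. On these data alone, it is also open whether the amide hydrogen itself matters, as compound 1 alone lacks it and also carries a methoxy group, and a plain dimethylamino or azetidin-1-yl group on the carbonyl carbon would separate those two features.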